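Cytotoxicity of Compound 3 after Removal of Bromo

This account rests on a few compounds, and the source may have more. Where it says the series, first, only, none or still open, it means among the compounds named here.

Measured so far:
compound 1 `COc1cc(-c2nnc(SCc3cccc([N+](=O)[O-])c3)o2)ccc1O`: 392000 nM
compound 2 `COc1cc(-c2nnc(SCc3ccccc3Br)o2)ccc1O`: 363000 nM

In an ADME assay on cells (Mus musculus, strain BALB/c) for cytotoxicity, read by MTT assay, with a stated time of 24 h (a higher number here means that more compound is tolerated, a lower number that less compound is tolerated), compound 1 gives 392000 nM and compound 2 gives 363000 nM. Compound 2 holds the lower of the two numbers, but its gap to compound 1 lies within the scatter, so the two stand level. Compound 3 `COc1cc(-c2nnc(SCc3ccccc3)o2)ccc1O` is not yet measured. It differs from compound 2 by hydrogen in place of bromo on an aromatic carbon. Within the data shown here, no step between measured compounds is available to gauge this change, and a step no larger than the scatter, in either direction, is expected, as a 1.0-fold higher number from compound 2 to compound 3 (0.02 log units; within the scatter). Compound 3 is thus estimated at 380000 nM, within 200000 nM to 720000 nM.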

Compound 3, half-maximal cytotoxic concentration: 211000 nM
The estimate for compound 3 lay 1.8-fold (0.26 log units) above the measured number, and the stated range covers the measured number.
By their numbers in this assay, from the lowest: compounds 3, 2 and 1 (each within the scatter of the next).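

In this assay the change from 2-bromophenyl to phenyl gives a 1.7-fold lower number from compound 2 to compound 3 (0.24 log units; within the scatter) and hydrogen in place of nitro gives a 1.9-fold lower number from compound 1 to compound 3 (0.27 log units; within the scatter) so neither bromo nor nitro on this aromatic ring is set apart from plain hydrogen by these numbers. The first direct view of this change at this place therefore shows a step that stays within the scatter. No measurement at hand speaks to the reason for these steps.

The compounds shown leave open whether an amine or a carboxylic acid on this aromatic carbon would give a step beyond the scatter. They also leave open whether bromo would read the same at another place on the ring.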